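Acetyl to dimethylamino swap on the terminal phenyl

This account rests on a few compounds, and the source may have more. Where it says the series, first, only, none or still open, it means among the compounds named here.

Three compounds have numbers in a functional assay on NCI-H522 cells (Homo sapiens) for inhibition, read by sulforhodamine B assay, with a stated time of 48 h; on this read-out lower numbers stand for stronger inhibition of growth and higher numbers for weaker inhibition of growth. Compound 1 `COc1cc(C)cc(-c2c(-c3ccnc(-c4ccc(C(C)=O)cc4)c3)cnn2CC#N)c1` gives 6960 nM, the second highest of the three. Compound 3 `Cc1cc(O)cc(-c2nn(CC#N)cc2-c2ccnc(-c3ccc(N(C)C)cc3)c2)c1` gives 7140 nM and compound 2 `COc1cc(C)cc(-c2nn(CC#N)cc2-c2ccc(-c3cccc(C(C)=O)c3)nc2)c1` gives 6720 nM; both lie within the scatter of compound 1, so no order among the three can be read. Compound 4 `COc1cc(C)cc(-c2c(-c3ccnc(-c4ccc(N(C)C)cc4)c3)cnn2CC#N)c1` has not yet been measured. It differs from compound 1 in one place: dimethylamino in place of acetyl on an aromatic carbon. Compound 3 also carries a dimethylamino on its phenyl and its number sits beside that of compound 1, though compound 3 differs elsewhere as well. Only a step within the scatter is expected in this assay, a 1.0-fold higher number from compound 1 to compound 4 (0.00 log units; within the scatter). Compound 4 is estimated at 7000 nM, in the range 3000 nM to 16000 nM.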

Compound 4, concentration for total growth inhibition: 84.6 nM
Compound 4: middle estimate off by 83-fold (1.92 log units), on the high side; the measured number lies below the stated range.
By their numbers in this assay, from the lowest: compound 4; then compounds 2, 1 and 3 (each within the scatter of the next).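

In this assay the change from 4-acetylphenyl to 4-(dimethylamino)phenyl gives an 82-fold lower number from compound 1 to compound 4 (1.92 log units; beyond the scatter) and so shows that this aromatic carbon, para to a large group, is sensitive to its substituent. The earlier compounds shown here differ from one another in more than one place and could not show this. No measured evidence bears on the cause of this step.

Open, from the compounds shown here alone, is whether a primary amine, a methoxy group or a pyrrolidine at this carbon would match dimethylamino. Also open, going by these compounds, is whether the same swap carries the same step on a different core.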